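This account rests on a few compounds, and the source may have more. Where it says the series, first, only, none or still open, it means among the compounds named here.

Measured so far:
compound 1, `Nc1ccc(-c2cc(=O)c3c(N)ccc(Cl)c3o2)cc1`, 9.8 nM
compound 2, `Cc1ccc(N)c2c(=O)cc(-c3ccc(N)c(F)c3)oc12`, 15 nM

Both numbers come from a functional assay on MCF7 cells (Homo sapiens) for inhibition, in the absence of a further agent; a higher number here means a weaker inhibitor, a lower number a stronger inhibitor. Compound 2 stands within the scatter of compound 1, so the two measured compounds are not separated on this read-out; the shared core with a primary amine on the aryl substituent at the two-position gives low numbers in both cases, whatever the substituent pattern on the fused ring.

The next compound is compound 3, `Cc1cc(C)c2oc(-c3ccc(N)c(F)c3)cc(=O)c2c1N`. It differs from compound 2 by methyl in place of hydrogen on an aromatic carbon. Within the data shown here, no pair among the measured compounds shows a step of this kind, so there is no measured precedent for it. Given that the two measured compounds sit close together despite different substituents on the fused ring, the expectation for the step from compound 2 to compound 3 in this assay is small, most likely within the scatter, with no clear direction. Compound 3 is therefore estimated at 20 nM, in the range 7 nM to 60 nM, corresponding to an expected step of a 1.3-fold higher number from compound 2 to compound 3 (0.12 log units; within the scatter).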

Compound 3, half-maximal inhibitory concentration: 36 nM
Estimate against measurement, compound 3: 1.8-fold (0.26 log units) below; the measured number falls inside the stated range.
By their numbers in this assay, from the lowest: compounds 1 and 2 (each within the scatter of the next); then compound 3.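

In this assay, among these compounds, methyl in place of hydrogen on the aromatic carbon ortho to an amino group gives a 2.4-fold higher number from compound 2 to compound 3 (0.38 log units; beyond the scatter), the first single-place change that can be read. This is a modest step, but it lies beyond the scatter, so this position is not neutral on this read-out, even though compound 3 at 36 nM keeps a number in the nanomolar range. No measurement shown here bears on the reason for this step.

From the compounds shown here alone, whether an ethyl group, a methoxy group or a carboxylic acid on this same carbon would move the number in the same direction, or by a similar amount, remains open. Also open, going by these compounds, is whether the methyl step would carry over to the core of compound 1, which has a different substituent pattern on the fused ring.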